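The source may report more compounds than this note shows. Statements on the series, on what has been measured and on what is new or still open speak of the compounds shown alone.

Measured compounds:
Compound 1, `COc1cc(Nc2nc(C(=N)Nc3ccc(N4CCN(C)CC4)cc3)cc3c(-c4ccccc4)n[nH]c23)cc(OC)c1OC`, gives 3400 nM in a functional assay on HT-1080 cells (Homo sapiens) for cytotoxicity, read by MTT assay, with a stated time of 72 h; a lower number here means a stronger inhibitor, a higher number a weaker inhibitor.
Compound 2, `CN1CCN(c2ccc(NC(=N)c3cc4c(-c5ccccc5)n[nH]c4c(NC4CCCCC4)n3)cc2)CC1`, gives 650 nM.
Compound 3, `COc1cc(Nc2nc(C(=N)Nc3cccc(C(F)(F)F)c3)cc3c(-c4ccccc4)n[nH]c23)cc(OC)c1OC`, gives 6700 nM.

The difference between the core of compound 1 and the core of compound 3 is not broken down here. Compound 1 and compound 2 differ by cyclohexyl in place of 3,4,5-trimethoxyphenyl on a nitrogen on an aromatic ring, and this change gave a 5.2-fold lower number from compound 1 to compound 2 (0.72 log units; beyond the scatter). Compound 4, `N=C(Nc1cccc(C(F)(F)F)c1)c1cc2c(-c3ccccc3)n[nH]c2c(NC2CCCCC2)n1`, is not yet measured; it differs from compound 3 by cyclohexyl in place of 3,4,5-trimethoxyphenyl on a nitrogen on an aromatic ring, the same change at the same place. For compound 4 the expected step is a 5.2-fold lower number from compound 3 to compound 4 (0.71 log units; beyond the scatter), because the same change gave a 5.2-fold lower number from compound 1 to compound 2 (0.72 log units; beyond the scatter) on a single pair only. Compound 4 is therefore estimated at 1300 nM, with a range from 550 nM to 3200 nM.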

Compound 4, half-maximal inhibitory concentration: 21200 nM
Compound 4: middle estimate off by 16-fold (1.21 log units), on the low side; the measured number lies above the stated range.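

In this assay, cyclohexyl in place of 3,4,5-trimethoxyphenyl on a nitrogen on an aromatic ring gives a 3.2-fold higher number from compound 3 to compound 4 (0.50 log units; beyond the scatter), so this change does not carry a single effect from one core to the other: the same change on two cores in this assay, a 5.2-fold lower number (0.72 log units; beyond the scatter) from compound 1 to compound 2 and a 3.2-fold higher number (0.50 log units; beyond the scatter) from compound 3 to compound 4, 17-fold (1.22 log units) apart, beyond the scatter of two such steps

A value measured on one core therefore cannot be transferred to the other for this change. With one pair per core, the data show that the direction differs but not which structural difference between the cores goes with the reversal.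

On these data alone, it remains open which direction the change takes on further cores. As far as these compounds go, it is also open whether another group on that nitrogen, such as benzyl or cyclopentyl, would follow the trend of compound 2 or that of compound 4.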